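The source may hold more compounds than are shown below. What is called first, only, known or untested is meant among the compounds shown, and "the series" means these compounds.

Measured so far:
Compound 1 `COc1ccc([C@H]2CC(=O)N(c3cc(N)cc(N)c3)C2)cc1OC1CCCC1`: > 10000 nM, a limit
Compound 2 `COc1ccc([C@H]2CC(=O)N(c3cc(N)cc(F)c3)C2)cc1OC1CCCC1`: > 10000 nM, a limit
Compound 3 `COc1ccc([C@H]2CC(=O)N(c3ccc(C#N)cc3)C2)cc1OC1CCCC1`: > 10000 nM, a limit

All three compounds were tested in a functional assay on HEK293 cells (Homo sapiens) for cytotoxicity; a lower number here means that less compound is tolerated, a higher number that more compound is tolerated. Compound 3 has no number there, only the limit > 10000 nM. It shares this position with the other two compounds, giving (the limit of > 10000 nM in this assay, at which 3 of the 3 values shown sit).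

Compound 4 `COc1ccc([C@H]2CC(=O)N(c3ccccc3C(F)(F)F)C2)cc1OC1CCCC1` keeps the shared core and carries 2-(trifluoromethyl)phenyl in place of 4-cyanophenyl on an amide-type nitrogen in a ring. The counted difference is 2-(trifluoromethyl)phenyl in place of 4-cyanophenyl on an amide-type nitrogen in a ring.

Among the compounds with values here, three measured steps bear on this change, as each alters the group on that nitrogen. They are a step that the two limits leave unreadable from compound 1 to compound 2, then a step that the two limits leave unreadable from compound 1 to compound 3, and finally a step that the two limits leave unreadable from compound 2 to compound 3. None of them has a size that can be read, so they give neither a magnitude nor a direction for the new change. No step beyond the scatter is expected in this assay. This expectation rests on compound 3 and its limit, > 10000 nM. The expected outcome is a step that the limit leaves unreadable from compound 3 to compound 4. Compound 4 is therefore estimated at 15000 nM, with an expected range from 6000 nM to 50000 nM, and a report of a limit rather than a number is the likeliest result.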

Compound 4, half-maximal cytotoxic concentration: > 10000 nM
Compound 4 was reported as a limit; the forecaster's own chance of this, stated with the estimate: 85%; the middle value does not contradict the limit.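

In this assay compound 4 gives > 10000 nM, which is a limit and not a number. Its steps to compound 1, compound 2 and compound 3 cannot be read, since all four compounds stand at a limit: the limit of > 10000 nM in this assay, at which 4 of the 4 values shown sit.

The compounds shown leave open how much compound is tolerated beyond that limit, and whether the group on the amide-type nitrogen has any effect on it.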